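Aryl amide in place of acetyl on the shared core

The compounds below may be only part of what the source reports. "The series", "measured", "known", "first", "only" and "open" are said of these compounds alone.

Among the measured compounds shown here, compound 1 `COc1ccc(CNC(=O)CSc2nc3ccc(NC(C)=O)cc3s2)cc1` gives 20500 nM in a functional assay on MCF7 cells (Homo sapiens) for cytotoxicity, read by MTT assay, with a stated time of 48 h (a higher number here means a weaker inhibitor, a lower number a stronger inhibitor), the only plain number among the values shown. Compound 2 `CNC(=O)CSc1nc2ccc(NC(C)=O)cc2s1` in this assay reaches only the limit > 100000 nM. The step of an at least 4.8-fold higher number from compound 1 to compound 2 (0.68 log units; beyond the scatter) shows that taking away the 4-methoxyphenyl from the saturated chain carbon bound to the amide-type nitrogen weakens the inhibitor. One of the two values shown sits at the limit of > 100000 nM in this assay, at which 1 of the 2 values shown sits. Compound 3 `COc1ccc(CNC(=O)CSc2nc3ccc(NC(=O)c4ccccc4OC)cc3s2)cc1` keeps that group and differs from compound 1 by 2-methoxyphenyl in place of methyl on a carbonyl carbon, which reads as acetyl to (2-methoxyphenyl)carbonyl. No measured step touches this carbonyl carbon; the single step shown concerns the other end of the molecule and offers no direct guide. With nothing beyond the scatter pointing either way, a step of about the scatter is expected, a 1.7-fold lower number from compound 1 to compound 3 (0.23 log units; within the scatter). Compound 3 is therefore estimated at 12000 nM, with a range from 3000 nM to 50000 nM.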

Compound 3, half-maximal inhibitory concentration: 9300 nM
Compound 3: the middle estimate sits 1.3-fold (0.11 log units) above what was measured; measured number inside the range.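

In this assay, 2-methoxyphenyl in place of methyl on the carbonyl carbon gives a 2.2-fold lower number from compound 1 to compound 3 (0.34 log units; beyond the scatter). This shows that the acetamido end of the molecule, which the earlier step did not touch, also shifts the number, and that this position takes a six-membered aromatic ring with no loss of inhibition. Nothing given here accounts for the size or direction of this step.

The compounds shown do not separate the contribution of the ring from that of its methoxy group, a question that a plain phenyl on this carbonyl carbon would address. They also leave open how a saturated ring such as cyclohexyl, or a longer chain ending in an amine, would behave at this position.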